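This account rests on a few compounds, and the source may have more. Where it says the series, first, only, none or still open, it means among the compounds named here.

Compound 1 `COc1ncc(-c2ccc3nc(NC(=O)C4CC4)nn3c2)cc1NS(=O)(=O)c1ccc(F)cc1`: 2590 nM
Compound 2 `O=C(Nc1nc2ccc(-c3cnc(Cl)c(NS(=O)(=O)c4ccc(F)cc4)c3)cn2n1)C1CC1`: > 60000 nM

In a functional assay on MCF7 cells (Homo sapiens) for antiproliferative activity, read by MTT assay, with a stated time of 48 h (on this read-out higher numbers stand for weaker inhibition and lower numbers for stronger inhibition), compound 1 holds the only number shown. Compound 2 reaches only (the limit of > 60000 nM in this assay, at which 1 of the 2 values shown sits), which is a limit of the assay and not a number. For the measured compounds named here, the one measured step, from compound 1 to compound 2, is an at least 23-fold higher number from compound 1 to compound 2 (1.36 log units; beyond the scatter) and comes from chloro in place of methoxy on an aromatic carbon.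

Compound 3 `CCOCCNc1nc2ccc(-c3cnc(OC)c(NS(=O)(=O)c4ccc(F)cc4)c3)cn2n1` differs from compound 1 elsewhere: 2-ethoxyethyl in place of cyclopropylcarbonyl on a nitrogen on an aromatic ring. The measured step concerns a different part of the shared core, so no measured step bears on this change, and the data give no cause to lean on. Exchanging the cyclopropylcarbonyl for a 2-ethoxyethyl chain at that ring nitrogen is a change of a kind not covered here, and the expectation is therefore wide. Compound 3 is expected to show 9000 nM, with a range of 2500 nM to 40000 nM. This estimate amounts to a 3.5-fold higher number from compound 1 to compound 3 (0.54 log units; beyond the scatter), a weakening expected beyond the scatter.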

Compound 3, half-maximal inhibitory concentration: 1350 nM
The estimate for compound 3 lay 6.7-fold (0.82 log units) above the measured number, outside the stated range (below it).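

At this nitrogen, 2-ethoxyethyl in place of cyclopropylcarbonyl gives a 1.9-fold lower number from compound 1 to compound 3 (0.28 log units; within the scatter) in this assay, so the two compounds read as equal on this measure. The carbonyl and the three-membered ring of compound 1 are both gone in compound 3, and the number stays in the same range, so neither is needed at this position for activity of this size in this assay. No measurement given here speaks to the reason for this result.

The compounds shown leave open how much more this nitrogen accepts, for instance a free amine with no chain at all, a longer chain, or a chain ending in a carboxylic acid. They also leave open whether the oxygen of the 2-ethoxyethyl chain matters, which a plain chain of carbon only would test.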